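Methanesulfonylphenyl and methoxyphenyl cyclohexanone analgesics: aryl methyl step

The source may hold more compounds than are shown below. What is called first, only, known or untested is meant among the compounds shown, and "the series" means these compounds.

Measured so far:
compound 1 `CN(CC1CCC/C(=C\c2ccc(S(C)(=O)=O)cc2)C1=O)c1ccccc1` 81%
compound 2 `Cc1cccc(N(C)CC2CCC/C(=C\c3ccc(S(C)(=O)=O)cc3)C2=O)c1` 72.8%
compound 3 `COc1ccc(C2(O)/C(=C/c3ccc(C)cc3)CCCC2CN(C)c2ccccc2)cc1` 72.1%

In a functional assay on the whole organism (strain Kunming) for inhibition, with Mus musculus as the target, in the writhing test, with stated times of 1 h and 15 min, at a dose of 200 mg/kg by the oral route (a lower number here means less inhibition, a higher number more inhibition at the dose given (going by the name of the read-out)), compound 1 gives 81%. The change to compound 2 is methyl in place of hydrogen on an aromatic carbon; the step of a number 8.2 percentage points lower from compound 1 to compound 2 (within the scatter) is recorded, and in this assay compound 2 gives 72.8%.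

Compound 3 belongs to a second core; the difference between the two cores is not broken down here. In this assay compound 3 gives 72.1%, a number within the scatter of both compound 1 and compound 2.

Compound 4 `COc1ccc(C2(O)/C(=C/c3ccc(C)cc3)CCCC2CN(C)c2ccc(C)cc2)cc1` has not been measured. It is obtained from compound 3 by methyl in place of hydrogen on an aromatic carbon. This is the same kind of change as from compound 1 to compound 2, but not the same: there the methyl sits meta to a large group, here para to a large group, and the core differs. Because the recorded step a number 8.2 percentage points lower from compound 1 to compound 2 (within the scatter) lies within the scatter, the step of a number 2.1 percentage points lower from compound 3 to compound 4 (within the scatter) is expected to be small as well. Compound 4 is thus expected to give about 70% in this assay, between 55% and 85%.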

Compound 4, a percentage reported as inhibition, in the whole organism at one dose (the size of the read-out at that dose, not a potency): 62.2%
Estimate against measurement, compound 4: 7.8 percentage points above; measured number inside the range.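

Methyl in place of hydrogen on an aromatic carbon, here phenyl to 4-methylphenyl, gives in this assay the step of a number 9.9 percentage points lower from compound 3 to compound 4 (within the scatter). Set beside the earlier step, the change reads alike on both cores: the same change on two cores in this assay, a number 8.2 percentage points lower (within the scatter) from compound 1 to compound 2 and a number 9.9 percentage points lower (within the scatter) from compound 3 to compound 4, 1.7 percentage points apart, within the scatter of two such steps. This shows that, in these two pairs, carrying the change to the other core brings no difference that can be told from the scatter, but it does not show that the methyl has a real effect on either core, nor that the two steps would match with the methyl placed alike, since the two pairs differ in where the methyl sits as well as in the core.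

The compounds shown leave open how this assay would respond to anything other than methyl on this ring, such as a chlorine atom, an ethyl group or a carboxylic acid. They also leave open whether the two steps would stay alike at other doses, as each number is a single-dose reading and not a potency.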